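Swapping One Halogenated Phenyl Group on a Weak Cytotoxic Compound

The source may hold more compounds than are shown below. What is called first, only, known or untested is meant among the compounds shown, and "the series" means these compounds.

Measured so far in a functional assay on HeLa cells (Homo sapiens) for cytotoxicity, read by CCK-8 assay, with a stated time of 72 h; on this read-out lower numbers stand for stronger inhibition and higher numbers for weaker inhibition:
- compound 1, `C=CCn1c(=O)/c(=C\c2ccc(Cl)c(Cl)c2)[nH]c(=O)/c1=C\c1ccccc1`, compound 1 gives "not active" (no number reported)
- compound 2, `C=CCn1c(=O)/c(=C\c2cccc(F)c2)[nH]c(=O)/c1=C\c1ccccc1OC`, compound 2 gives 9100 nM
- compound 3, `COc1ccccc1/C=c1/[nH]c(=O)/c(=C\c2nc[nH]c2C(C)(C)C)[nH]c1=O`, compound 3 gives 80 nM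

Among the two numbers reported, compound 2 stands highest, meaning the weakest inhibition; compound 3 sits far lower, beyond the scatter, while compound 1 has no number at all. The new compound 4, `C=CCn1c(=O)/c(=C\c2ccccc2Cl)[nH]c(=O)/c1=C\c1ccccc1OC`, is built from compound 2 by one change: 2-chlorophenyl in place of 3-fluorophenyl on a double-bonded chain carbon bound to an aromatic carbon. For the measured compounds named here, no measured pair shows what such a swap does here, so in this assay no step beyond the scatter is expected in either direction for compound 4. The expected step is a 1.0-fold lower number from compound 2 to compound 4 (0.00 log units; within the scatter), an estimate that carries wide uncertainty. Compound 4 is estimated at 9000 nM, within 3000 nM to 30000 nM.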

Compound 4, half-maximal inhibitory concentration: 5100 nM
Compound 4: the middle estimate sits 1.8-fold (0.25 log units) above what was measured; the measured number falls inside the stated range.
By their numbers in this assay, from the lowest: compound 3; then compounds 4 and 2 (each within the scatter of the next).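

For the compounds shown here, the pair shows a 1.8-fold lower number from compound 2 to compound 4 (0.25 log units; within the scatter) in this assay and is the first direct comparison at this place on the molecule. On a double-bonded chain carbon bound to an aromatic carbon, 2-chlorophenyl and 3-fluorophenyl cannot be told apart in this read-out, even though both the halogen and its ring position differ. Nothing available here explains this result.

As far as these compounds go, with both features differing in one step, their separate contributions stay open. So does the outcome with a phenyl ring carrying an amine or a carboxylic acid at this place.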